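Swapping a Cyclopropyl Sulfonamide for an Ethynylpyrrolidine

The source may hold more compounds than are shown below. What is called first, only, known or untested is meant among the compounds shown, and "the series" means these compounds.

Measured compounds:
compound 1 `COc1ccc2c(OCC[C@@H]3NC(=O)N(C)CCCC/C=C\[C@@H]4C[C@@]4(C(=O)NS(=O)(=O)C4(C#N)CC4)NC3=O)cc(-c3nc(C(C)C)cs3)nc2c1Cl`: > 75000 nM
compound 2 `COc1ccc2c(OCC[C@@H]3NC(=O)N(C)CCCC/C=C\[C@@H]4C[C@@]4(C(=O)NS(=O)(=O)N4CCC[C@H]4C#N)NC3=O)cc(-c3nc(C(C)C)cs3)nc2c1Cl`: 28300 nM
compound 3 `COc1ccc2c(OCC[C@@H]3NC(=O)N(C)CCCC/C=C\[C@@H]4C[C@@]4(C(=O)NS(=O)(=O)C4(C)CC4)NC3=O)cc(-c3nc(C(C)C)cs3)nc2c1Cl`: 37400 nM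

In an ADME assay on cells (Homo sapiens) for activation (a lower number here means that less compound is tolerated, a higher number that more compound is tolerated), compound 3 gives 37400 nM, the highest of the two plain numbers shown, although its gap to compound 2 lies within the scatter. Compound 1 gives only a limit of the assay, > 75000 nM, not a number. Compound 4 `C#C[C@@H]1CCCN1S(=O)(=O)NC(=O)[C@@]12C[C@H]1/C=C\CCCCN(C)C(=O)N[C@@H](CCOc1cc(-c3nc(C(C)C)cs3)nc3c(Cl)c(OC)ccc13)C(=O)N2` differs from compound 3 in one place: 2-ethynylpyrrolidin-1-yl in place of 1-methylcyclopropyl on a sulfonyl sulfur. The measured step that bears most directly on this is a 1.3-fold higher number from compound 2 to compound 3 (0.12 log units; within the scatter), an exchange of ring groups at the same sulfonyl sulfur. Within the data shown here, no measured compound carries the 2-ethynylpyrrolidin-1-yl group itself. Compound 4 is therefore expected to show a 1.2-fold lower number from compound 3 to compound 4 (0.10 log units; within the scatter). The estimate for compound 4 is 30000 nM, from 12000 nM to 75000 nM.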

Compound 4, half-maximal cytotoxic concentration: 21200 nM
For compound 4 the middle estimate is 1.4-fold (0.15 log units) above the measured one, and the stated range covers the measured number.
By their numbers in this assay, from the lowest: compounds 4, 2 and 3 (each within the scatter of the next). At a limit, above all of these: compound 1.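

For the sulfonyl sulfur, compound 4 shows that 2-ethynylpyrrolidin-1-yl can be read in this assay, and a 1.8-fold lower number from compound 3 to compound 4 (0.25 log units; within the scatter) stays small. Ethynyl in place of cyano on the same ring gives a 1.3-fold lower number from compound 2 to compound 4 (0.13 log units; within the scatter), so this change does not separate the two compounds. Among these compounds, the only step beyond the scatter is an at least 3.5-fold lower number from compound 1 to compound 4 (0.54 log units; beyond the scatter), and it gives only a floor, since compound 1 stands at a limit: the limit of > 75000 nM in this assay, at which 1 of the 4 values shown sits.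

Still open, on these data alone, is how an amine or a carboxylic acid in place of ethynyl on that saturated ring carbon would read.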